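The compounds below may be only part of what the source reports. "The series", "measured", "known", "first", "only" and "open" are said of these compounds alone.

Measured compounds:
Compound 1, `COc1ccc(/C=C2\CN(C)CC3=C2N=C(S)NC3c2ccc(OC)cc2)cc1`: 6500 nM
Compound 2, `CN1C/C(=C\c2cccs2)C2=NN(C)C(c3cccs3)C2C1`: 86400 nM

Compound 2, `CN1C/C(=C\c2cccs2)C2=NN(C)C(c3cccs3)C2C1`, was tested in a functional assay on NSCLC cells (Homo sapiens) for inhibition (a lower number here means a stronger inhibitor of growth, a higher number a weaker inhibitor of growth), where compound 2 gives 86400 nM. Compound 1, `COc1ccc(/C=C2\CN(C)CC3=C2N=C(S)NC3c2ccc(OC)cc2)cc1`, gives 6500 nM in this assay, so compound 2 carries the higher of the two numbers, and the gap between them lies beyond the scatter. The two compounds share no single point of difference, so nothing more than that comparison can be drawn from them.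

Compound 3, `CN1C/C(=C\c2cccs2)C2=NN(c3ccccc3)C(c3cccs3)C2C1`, has not yet been measured in this assay. It is built from compound 2 by one change: phenyl in place of methyl on an amine nitrogen in a ring. For the measured compounds named here, no measured pair shows the outcome of this change, so the expectation rests on compound 2 alone as a starting point. A step of modest size toward a lower number is expected, a 2.9-fold lower number from compound 2 to compound 3 (0.46 log units; beyond the scatter), though a step that stays within the scatter would not surprise. For compound 3 the estimate in this assay is 30000 nM, with a range from 8000 nM to 120000 nM.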

Compound 3, concentration for 50% growth inhibition: 20800 nM
Estimate against measurement, compound 3: 1.4-fold (0.16 log units) above, and the stated range covers the measured number.
By their numbers in this assay, from the lowest: compound 1; then compound 3; then compound 2.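

In this assay, for the compounds shown here, this is the first measured change at the amine nitrogen in the five-membered non-aromatic ring with 2 nitrogen: with phenyl in place of methyl, the result is a 4.2-fold lower number from compound 2 to compound 3 (0.62 log units; beyond the scatter) and so a modest gain beyond the scatter. The position therefore accepts an entering group of 6 heavy atoms and one six-membered aromatic ring in place of a methyl of 1 heavy atom, with no loss of growth inhibition, even though it lies next to the ring atom that bears a thiophen-2-yl group. No measurement of any property accompanies these compounds, so the data give no explanation for the step.

From the compounds shown here alone, with only methyl and phenyl seen here, it remains open whether the gain follows the aromatic ring itself or simply the larger group, a question that an ethyl, a benzyl or a cyclohexyl group on the same nitrogen would address. Going by these compounds, it also remains open whether a pyridyl ring or a phenyl bearing a methoxy or a fluorine would move the number further in either direction.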